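A few compounds are considered here, and "the series" means these few. Any claim that something is new, unique, unknown or untested is made for them only; others in the source may bear on it.

Three compounds have been measured in an ADME assay on KB cells (Homo sapiens) for cytotoxicity, read by MTT assay, with a stated time of 44 h; a lower number here means a stronger inhibitor, a higher number a weaker inhibitor:

compound 1 `CCCCNC(=S)N/N=C\c1c[nH]c2ccccc12` gives > 100000 nM, which is a limit of the assay.
compound 2 `Cc1ccc(NC(=S)N/N=C\c2c[nH]c3ccccc23)cc1` gives > 100000 nM, which is a limit of the assay.
compound 3 `CCCCN(C)C(=S)N/N=C\c1c[nH]c2ccccc12` gives > 100000 nM, which is a limit of the assay.

Compound 1 therefore stands only at a limit in this assay, with no number of its own. Nothing places it apart from the other two, whose readings are also limits. The step that the two limits leave unreadable from compound 1 to compound 2 and the step that the two limits leave unreadable from compound 1 to compound 3 cannot be sized, because every reading sits at the limit of > 100000 nM in this assay, at which 3 of the 3 values shown sit.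

Compound 4 `S=C(NCc1ccccc1Cl)N/N=C\c1c[nH]c2ccccc12` has not yet been measured. It differs from compound 1 by 2-chlorophenyl in place of propyl on a saturated chain carbon bound to an amide-type nitrogen. The two measured steps are the only ones that bear on this change, and neither gives a readable size or direction; earlier changes at the amide-type nitrogen left every reading at the limit. Compound 4 is therefore expected to sit at that same limit, with an expected step of a number no higher from compound 1 to compound 4 (the limit leaves the size open) of no readable size. The estimate for compound 4 is 100000 nM, within the range 30000 nM to 300000 nM.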

Compound 4, half-maximal inhibitory concentration: > 100000 nM
Compound 4: only a limit was reported; the forecaster's own chance of this, stated with the estimate: 85%; the middle value sits exactly at the limit.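

In this assay compound 4 gives > 100000 nM, which is a limit of the assay. For the compounds shown here, no step from compound 1 to compound 4 can be read, because both sit at the same limit: the limit of > 100000 nM in this assay, at which 4 of the 4 values shown sit. The compounds shown leave open which change, if any, would give a reading with a number of its own.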